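Chloro in Place of Vinyl on a Weak Series

The compounds below may be only part of what the source reports. "The series", "measured", "known", "first", "only" and "open" are said of these compounds alone.

This account follows a small set of compounds built on the shared core, all tested in an assay on cells for inhibition of HSP60/HSP10 (Homo sapiens), with a stated time of 60 min; a lower number here means a stronger inhibitor, a higher number a weaker inhibitor. Compound 1 `O=S(=O)(Nc1ccc(-c2nc3cc(NS(=O)(=O)c4cccs4)ccc3o2)cc1)c1cccs1` gives 40000 nM in this assay, and compound 3 `O=S(=O)(Nc1ccc2oc(-c3ccccc3)nc2c1)c1ccc(F)c(C(F)(F)F)c1` gives 69000 nM in this assay. Compound 2 `C=Cc1ccc(S(=O)(=O)Nc2ccc3oc(-c4ccccc4)nc3c2)cc1` did not reach a number in this assay: its result is the limit > 100000 nM. This is the limit of > 100000 nM in this assay, at which 1 of the 3 values shown sits. Compound 2 therefore stands at the weak edge of what has been seen so far, with only a limit and no value of its own to compare against compound 1 or compound 3. For the measured compounds named here, no pair of measured compounds differs in a single place, so nothing measured yet tells how much one change on the outer ring moves the result.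

Compound 4 `O=S(=O)(Nc1ccc2oc(-c3ccccc3)nc2c1)c1ccc(Cl)cc1` differs from compound 2 by chloro in place of vinyl on an aromatic carbon. Because compound 2 sits at a limit, the step of an at least 1.2-fold lower number from compound 2 to compound 4 (0.09 log units; that floor lies within the scatter) is expected to be small, no more than the usual scatter or a little beyond it, and may not bring compound 4 into the measurable range at all. Compound 4 is estimated at 80000 nM, with a likely range from 30000 nM to 300000 nM, and a limit rather than a number is almost as likely.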

Compound 4, half-maximal inhibitory concentration: > 100000 nM
Compound 4: no number, only a limit; the forecaster's own chance of this, stated with the estimate: 45%; middle value at least 1.2-fold (0.09 log units) away from the limit.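

In this assay compound 4 gives > 100000 nM as a limit and not a number. For the compounds shown here, compound 2 also stands at a limit, so chloro in place of vinyl between compound 2 and compound 4 gives no step that can be read. The compounds shown leave open whether this change moves the result at all, and by how much.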